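Drawing One Stereocentre: From Compound 2 to Compound 4

The compounds below may be only part of what the source reports. "The series", "measured", "known", "first", "only" and "open" are said of these compounds alone.

Compound 1 `COc1ccc(/C=C\c2cc(OC)c(OC)c(OC)c2)cc1OCc1ccc(CN2CC(C(=O)O)C2)cc1`: in a functional assay on HepG2 cells (Homo sapiens) for antiproliferative activity, read by CCK-8 assay, with a stated time of 48 h (on this read-out lower numbers stand for stronger inhibition and higher numbers for weaker inhibition), compound 1 gives only a limit, > 10000 nM.
Compound 2 `COc1ccc(/C=C\c2cc(OC)c(OC)c(OC)c2)cc1OCc1ccc(CN2CCCCC2C(=O)O)cc1`: in this assay compound 2 gives 3100 nM.
Compound 3 `COc1ccc(/C=C\c2cc(OC)c(OC)c(OC)c2)cc1OCc1ccc(CNCCNC(C)=O)cc1`: in this assay compound 3 gives 6100 nM.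

Among the two numbers shown, compound 2 has the lowest; compound 3 sits nearest, and the gap a 2.0-fold higher number from compound 2 to compound 3 (0.29 log units; within the scatter) is within the scatter, so the two cannot be ranked. The value of compound 1 is a limit, (the limit of > 10000 nM in this assay, at which 1 of the 3 values shown sits), not a number. The step of an at least 3.2-fold lower number from compound 1 to compound 2 (0.50 log units; beyond the scatter) is therefore at least modest, while an at least 1.6-fold lower number from compound 1 to compound 3 (0.21 log units; that floor lies within the scatter) has a floor that lies within the scatter.

Compound 4 `COc1ccc(/C=C\c2cc(OC)c(OC)c(OC)c2)cc1OCc1ccc(CN2CCCC[C@@H]2C(=O)O)cc1` differs from compound 2 only in how one part is drawn: the two compounds have the same atoms and bonds; at least one stereo element is drawn with a configuration in one of them and without one in the other: 1 of 2 stereo elements differ; a stereocentre at a saturated ring carbon is drawn without a configuration in compound 2 and R in compound 4. Going by the values given here, no measured step touches a stereocentre alone; the steps from compound 1 and to compound 3 each swap a whole group at the saturated chain carbon bound to an aromatic carbon, and so they give no guide to this change. With nothing to point either way, the step of a 1.2-fold lower number from compound 2 to compound 4 (0.09 log units; within the scatter) is expected to stay within the scatter. Compound 4 is estimated at 2500 nM in this assay, with a range from 900 nM to 8000 nM.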

Compound 4, half-maximal inhibitory concentration: > 10000 nM
Compound 4: no number, only a limit; the forecaster's own chance of this, stated with the estimate: 5%; at least 4.0-fold (0.60 log units) between middle value and limit.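

Compounds 1, 2 and 3 differ by whole groups, so they say nothing about the arrangement in space at any one carbon. Compounds 2 and 4 keep the same atoms and bonds and differ only in how a saturated ring carbon of the 2-carboxypiperidin-1-yl group is drawn, yet this assay shows an at least 3.2-fold higher number from compound 2 to compound 4 (0.50 log units; beyond the scatter), so this stereocentre alone goes with a change beyond the scatter. The comparison with the open-chain amide is less firm, since an at least 1.6-fold higher number from compound 3 to compound 4 (0.21 log units; that floor lies within the scatter) does not allow compound 3 and compound 4 to be ranked, and compound 1 and compound 4 both give only a limit, so the step joining them cannot be read: the limit of > 10000 nM in this assay, at which 2 of the 4 values shown sit.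

The compounds shown do not tell what compound 2 holds at that carbon, so the source of the gap stays unsettled: the fact that one of compounds 2 and 4 is drawn with a defined configuration and the other without, at the place where they differ How the form drawn S at the same ring carbon, or a methyl ester in place of the carboxylic acid, would read in this assay also stays open.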